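Adding an amino group to compound 1

A few compounds are considered here, and "the series" means these few. Any claim that something is new, unique, unknown or untested is made for them only; others in the source may bear on it.

Compound 1 `C[C@H](NC(=O)c1cccc(F)c1)c1ccc(NC(=O)N2CC(c3cccnc3)C2)cc1`: 60.9 mL.min-1.g-1
Compound 2 `CCC(=O)N[C@@H](C)c1ccc(NC(=O)N2CC(c3cccnc3)C2)cc1`: 31.4 mL.min-1.g-1

In an ADME assay on microsomes from liver (Mus musculus) for pharmacokinetics, read by LC-MS, using NADPH, with stated times of 5 min, 15 min and 30 min, tested at 10 uM (a lower number here means slower removal, a higher number faster removal of the compound), compound 1 has one measured neighbour, compound 2, and the two lie within the scatter of each other. Compound 3 `C[C@H](NC(=O)c1cccc(F)c1)c1ccc(NC(=O)N2CC(c3ccc(N)nc3)C2)cc1` differs from compound 1 in one place: amino in place of hydrogen on an aromatic carbon. Here pyridin-3-yl becomes 6-aminopyridin-3-yl. For the measured compounds named here, the only measured step, a 1.9-fold lower number from compound 1 to compound 2 (0.29 log units; within the scatter), swaps 3-fluorophenyl for ethyl on a carbonyl carbon, so no measurement tests the amino group directly. No shift beyond the scatter is therefore expected, and the estimated step is a 1.2-fold lower number from compound 1 to compound 3 (0.09 log units; within the scatter). The expected value for compound 3 is 50 mL.min-1.g-1, with a range of 22 mL.min-1.g-1 to 110 mL.min-1.g-1.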

Compound 3, intrinsic clearance in microsomes: < 25 mL.min-1.g-1
Compound 3: only a limit was reported (the forecaster's own chance of this, stated with the estimate: 3%); middle value at least 2.0-fold (0.30 log units) from the limit.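

In this assay, the change from pyridin-3-yl to 6-aminopyridin-3-yl, on the aromatic carbon next to the ring nitrogen, gives an at least 2.4-fold lower number from compound 1 to compound 3 (0.38 log units; beyond the scatter). Compound 1 and compound 2, which differ on the carbonyl carbon, lie within the scatter of each other, so this is the first step beyond the scatter among the compounds shown. Compound 3 carries only a limit of the assay: the limit of < 25 mL.min-1.g-1 in this assay, at which 1 of the 3 values shown sits.

As far as these compounds go, what stays open is whether a methylamino group or a fluorine on this carbon would move the number the same way, and whether the amino group would do so on compound 2 as well.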